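This account rests on a few compounds, and the source may have more. Where it says the series, first, only, none or still open, it means among the compounds named here.

Compound 1 `Cn1cccc1-c1ccccc1NCC1=NCCN1` gives 103% in a functional assay with Alpha-1A adrenergic receptor (Homo sapiens) as the target, read by calcium flux; a lower number here means a smaller maximal response, a higher number a larger maximal response.
Compound 2 `CCCCn1ncnc1-c1ccccc1NCC1=NCCN1` gives 86% in this assay.
Compound 3 `CCn1cccc1-c1ccccc1NCC1=NCCN1` gives 93% in this assay.

Compound 1 stands highest of the three numbers. Its nearest neighbour is compound 3, and the step of a number 10 percentage points lower from compound 1 to compound 3 (within the scatter) lies within the scatter, so the two cannot be ordered. For the measured compounds named here, compound 2 lies furthest away, with a value lower than that of compound 1 by more than the scatter; the two differ in more than one place, so no single step is drawn between them.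

Compound 4 `Cn1nccc1-c1ccccc1NCC1=NCCN1` has not yet been measured. It differs from compound 1 in one place: 1-methyl-1H-pyrazol-5-yl in place of 1-methyl-1H-pyrrol-2-yl on an aromatic carbon.

Going by the values given here, no measured step exchanges one five-membered ring for another. Among the compounds with values here, the only single-place step, a number 10 percentage points lower from compound 1 to compound 3 (within the scatter), alters a chain on the ring nitrogen and stays within the scatter. Compound 2, which carries a ring with more hetero atoms than compound 1, gives a lower value, but that comparison also involves a longer chain. The expectation for compound 4 is therefore a step of a number 8 percentage points lower from compound 1 to compound 4 (within the scatter) of modest size, most likely within the scatter, with a lean toward a lower number. Compound 4 is estimated at 95%, in a range from 82% to 108%.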

Compound 4, largest response reached (reported as maximal response), in percent of the reference or control that the assay uses: 108%
For compound 4 the middle estimate is 13 percentage points below the measured one; the range from low to high includes it.
By their numbers in this assay, from the lowest: compounds 2, 3, 1 and 4 (each within the scatter of the next, the first and the last beyond it).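

In this assay, for the compounds shown here, the exchange of 1-methyl-1H-pyrrol-2-yl for 1-methyl-1H-pyrazol-5-yl gives a number 5 percentage points higher from compound 1 to compound 4 (within the scatter) and is the first measured step that replaces one five-membered aromatic ring with another. At this place, on an aromatic carbon and ortho to a group of 7 heavy atoms, a ring with 2 hetero atoms therefore stands in for a ring with 1 hetero atom with no change that can be told from the scatter, and the two compounds cannot be ordered. No measured property of these compounds bears on this result.

Still open, on these data alone, is whether the same place accepts a six-membered ring such as phenyl or pyridyl, or a five-membered ring carrying an amine or a carboxylic acid. Also open, as far as these compounds go, is how a longer chain on the ring nitrogen would act in the 1-methyl-1H-pyrazol-5-yl group, given that the corresponding change on the 1-methyl-1H-pyrrol-2-yl group gives a number 10 percentage points lower from compound 1 to compound 3 (within the scatter) and so offers no firm trend to carry across.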